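Swapping methyl for chloro in a cell growth test

The compounds below may be only part of what the source reports. "The series", "measured", "known", "first", "only" and "open" are said of these compounds alone.

Compound 1 `O=C(NO)N1CCN(C(=S)N/N=C/c2ccccc2Cl)CC1`: 30000 nM
Compound 2 `Cc1ccc(/C=N/NC(=S)N2CCN(C(=O)NO)CC2)cc1`: 51000 nM

In a functional assay on NCI-H460 cells (Homo sapiens) for cytotoxicity, read by MTT assay, with a stated time of 48 h (a higher number here means a weaker inhibitor of growth, a lower number a stronger inhibitor of growth), compound 2 gives 51000 nM and compound 1 gives 30000 nM, so compound 2 stands level with compound 1 within the scatter. Compound 3 `O=C(NO)N1CCN(C(=S)N/N=C/c2ccc(Cl)cc2)CC1` differs from compound 2 by one change: chloro in place of methyl on an aromatic carbon. Among the compounds with values here, the only measured step that bears on it is a 1.7-fold higher number from compound 1 to compound 2 (0.23 log units; within the scatter), which also trades a chlorophenyl for a methylphenyl. With that step inside the scatter, no step beyond the scatter, in either direction, is expected in this assay. The expected change is a 1.3-fold lower number from compound 2 to compound 3 (0.11 log units; within the scatter). For compound 3 the estimated value is 40000 nM, with an expected range of 18000 nM to 90000 nM.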

Compound 3, concentration for 50% growth inhibition: 16000 nM
Compound 3: the middle estimate sits 2.5-fold (0.40 log units) above what was measured, outside the stated range (below it).
By their numbers in this assay, from the lowest: compounds 3, 1 and 2 (each within the scatter of the next, the first and the last beyond it).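

In this assay, within the data shown here, the change from methyl to chloro on this aromatic carbon, para to a large group, gives a 3.2-fold lower number from compound 2 to compound 3 (0.50 log units; beyond the scatter) and is the first step here to lie beyond the scatter. Moving the chlorine, with 4-chlorophenyl in place of 2-chlorophenyl, gives a 1.9-fold lower number from compound 1 to compound 3 (0.27 log units; within the scatter) and so shows no clear effect of where the chloro sits. No measurement at hand explains the difference between methyl and chloro.

Going by these compounds, whether a methoxy group or an amine at this position would give a lower or higher number remains open. So does whether the same swap would matter elsewhere on the ring.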